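The source may report more compounds than this note shows. Statements on the series, on what has been measured and on what is new or still open speak of the compounds shown alone.

Measured so far: compound 1 `O=C(NC1CCN(c2ncnc3[nH]ncc23)CC1)c1ccc(F)cc1` with 4540 nM; compound 2 `Cc1ccc(NC(=O)NC2CCN(c3ncnc4[nH]ncc34)CC2)cc1` with 4710 nM.

In an assay on isolated protein for inhibition of serine/threonine-protein kinase PAK 1 (Homo sapiens), read by ADP-Glo, with a stated time of 40 min (a higher number here means a weaker inhibitor, a lower number a stronger inhibitor), compound 1 gives 4540 nM and compound 2 gives 4710 nM. Compound 2 thus sits alongside compound 1, the two numbers lying within the scatter of each other, as the step of a 1.0-fold higher number from compound 1 to compound 2 (0.02 log units; within the scatter) shows. That step is the only measured one, and it changes the carbonyl side rather than the aryl group of the urea. Compound 3 `Cc1cccc(C)c1NC(=O)NC1CCN(c2ncnc3[nH]ncc23)CC1` differs from compound 2 by 2,6-dimethylphenyl in place of 4-methylphenyl on an amide-type nitrogen. Among the compounds with values here, no measured step bears on this change, so nothing beyond the scatter is expected; the estimated step is a 1.1-fold higher number from compound 2 to compound 3 (0.03 log units; within the scatter). Compound 3 is expected to give 5000 nM, within 2000 nM to 13000 nM.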

Compound 3, half-maximal inhibitory concentration: 2160 nM
For compound 3 the middle estimate is 2.3-fold (0.36 log units) above the measured one; low and high end bracket the measured number.
By their numbers in this assay, from the lowest: compound 3; then compounds 1 and 2 (each within the scatter of the next).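

In this assay, within the data shown here, the aryl group of the urea now shows an effect: 2,6-dimethylphenyl in place of 4-methylphenyl on an amide-type nitrogen gives a 2.2-fold lower number from compound 2 to compound 3 (0.34 log units; beyond the scatter) and is the first step here beyond the scatter, though only a modest one. Set against the amide, the change to this urea gives a 2.1-fold lower number from compound 1 to compound 3 (0.32 log units; beyond the scatter) and so also lies beyond the scatter. No evidence at hand accounts for either step.

Going by these compounds, whether both added methyl groups are needed for this shift remains open. So does how a pyridine ring or a cyclohexyl group would read on this nitrogen.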